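Lengthening the Charged Nitrogen Substituent and Solubility

A few compounds are considered here, and "the series" means these few. Any claim that something is new, unique, unknown or untested is made for them only; others in the source may bear on it.

Of the compounds shown here, two have been measured in a physicochemical assay for solubility; on this read-out higher numbers stand for higher solubility and lower numbers for lower solubility. Compound 1, `COc1cc2cc(C(=O)CC(O)CCC3CC[N+](C)(Cc4ccccc4)CC3)sc2cc1OC`, gives 2500 ug/mL in this assay. Compound 2, `COc1cc2cc(C(=O)CCc3cc[n+](C)cc3)sc2cc1OC`, gives 3000 ug/mL in this assay, the higher of the two numbers, though its gap to compound 1 lies within the scatter of repeated measurements, so no order between them can be read from these values.

Compound 3, `CC[n+]1ccc(CCC(=O)c2cc3cc(OC)c(OC)cc3s2)cc1`, has not yet been measured. Its difference from compound 2 is methyl in place of hydrogen on a saturated chain carbon bound to an aromatic nitrogen; cut one bond further out, the same difference reads methyl to ethyl. Among the measured compounds shown here, no step between measured compounds shows what a change of this kind does in this assay. A single added carbon is expected to move the solubility little, most likely no further than the scatter, with a slight lean downward. Compound 3 is therefore estimated at 2500 ug/mL, within a range of 1200 ug/mL to 5000 ug/mL. The step of a 1.2-fold lower number from compound 2 to compound 3 (0.08 log units; within the scatter) is expected to stay within the scatter.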

Compound 3, solubility: 25000 ug/mL
The estimate for compound 3 lay 10-fold (1.00 log units) below the measured number; measured number above the stated range.
By their numbers in this assay, from the lowest: compounds 1 and 2 (each within the scatter of the next); then compound 3.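

The change of methyl in place of hydrogen on a saturated chain carbon bound to an aromatic nitrogen, which reads methyl to ethyl one bond further out, gives an 8.3-fold higher number from compound 2 to compound 3 (0.92 log units; beyond the scatter) in this assay and so marks this position as sensitive. The group that enters holds only 1 carbon, with no ring, 0 hydrogen-bond donors, 0 hydrogen-bond acceptors and no net charge, yet the step lies beyond the scatter, which compound 1 and compound 2 alone could not show. Nothing given here accounts for the size of this step.

Because this is a single step, it does not show a trend. On these data alone, whether a longer chain such as propyl, a branched isopropyl or a hydroxyethyl group at this position would carry the number further up or bring it back down remains open.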